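The compounds below may be only part of what the source reports. "The series", "measured", "known", "first", "only" and "open" are said of these compounds alone.

Measured so far in a functional assay on HepG2 cells (Homo sapiens) for antiproliferative activity, read by MTT assay, with a stated time of 72 h; a lower number here means a stronger inhibitor, a higher number a weaker inhibitor:
compound 1 `O=C1COc2ccc(-c3cnc(Cl)c(NS(=O)(=O)c4ccc(F)cc4)c3)cc2N1c1ccc(F)cc1` gives > 40000 nM, which is a limit of the assay and not a number.
compound 2 `O=C1COc2ccc(-c3cnc(Cl)c(NS(=O)(=O)c4ccc(F)cc4)c3)cc2N1` gives > 40000 nM, again a limit of the assay.
compound 3 `O=C1COc2ccc(-c3cnc4ccccc4c3)cc2N1c1ccc(F)cc1` gives 37200 nM.

Compounds 1 and 2 share one core and differ only by hydrogen in place of 4-fluorophenyl on an amide-type nitrogen in a ring. Both values sit at the limit of > 40000 nM in this assay, at which 2 of the 3 values shown sit, so the step that the two limits leave unreadable from compound 1 to compound 2 cannot be read in either direction; what the change does to activity in this assay is not known from this pair.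

Compound 3 has a different core. The difference between the core of compound 1 and the core of compound 3 is not broken down here. Compound 3 is the only one of the three that gives a number rather than a limit, and that number lies close to the limit at which the other two sit.

Compound 4 `O=C1COc2ccc(-c3cnc4ccccc4c3)cc2N1` is not yet measured. It differs from compound 3 by hydrogen in place of 4-fluorophenyl on an amide-type nitrogen in a ring, the same change, at the same place, as that from compound 1 to compound 2. The step from compound 3 to compound 4 is expected to be about a 1.2-fold higher number from compound 3 to compound 4 (0.08 log units; within the scatter). This expectation rests on compound 3 giving 37200 nM and on the step that the two limits leave unreadable from compound 1 to compound 2 being unreadable, so no direction of change is established. Compound 4 is thus expected to give around 45000 nM in this assay, with the estimate spanning 15000 nM to 120000 nM, and a limit rather than a number is the more likely read-out for compound 4.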

Compound 4, half-maximal inhibitory concentration: 26300 nM
The estimate for compound 4 lay 1.7-fold (0.23 log units) above the measured number; the measured number falls inside the stated range.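

In this assay, hydrogen in place of 4-fluorophenyl on the amide-type nitrogen gives a 1.4-fold lower number from compound 3 to compound 4 (0.15 log units; within the scatter), so on the core of compound 3 the two values cannot be told apart and the change shows no readable effect on antiproliferative activity. The same change on the core of compound 1 cannot be read, since compound 1 and compound 2 each give a limit of the assay and not a number: the limit of > 40000 nM in this assay, at which 2 of the 4 values shown sit. The series therefore offers one readable instance of this change and nothing to set it against, so these data neither show that the result carries from one core to the other nor show that it fails to carry, and the readable pair says nothing about the change in a clearly more active compound.

Going by these compounds, it remains open whether any other group on the amide-type nitrogen, such as methyl, a longer chain, a chain ending in an amine or one ending in a carboxylic acid, would give a step beyond the scatter on either core. The difference between the core of compound 1 and the core of compound 3 also remains unresolved into its separate parts.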